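Three Benzyl Acids at the Limit, a Fourth Awaits

The source may hold more compounds than are shown below. What is called first, only, known or untested is meant among the compounds shown, and "the series" means these compounds.

compound 1 `CC#CCn1c(N2CCC[C@@H](N)C2)nc2c1c(=O)n(Cc1cccc(F)c1C(=O)O)c(=O)n2C`: > 100000 nM
compound 2 `CC#CCn1c(N2CCC[C@@H](N)C2)nc2c1c(=O)n(Cc1cc(Cl)ccc1C(=O)O)c(=O)n2C`: > 100000 nM
compound 3 `CC#CCn1c(N2CCC[C@@H](N)C2)nc2c1c(=O)n(Cc1ccc(Br)cc1C(=O)O)c(=O)n2C`: > 100000 nM

In an ADME assay on isolated protein for inhibition of Dipeptidyl peptidase 9 (Homo sapiens), with stated times of 15 min, 60 s and 20 min (a lower number here means a stronger inhibitor, a higher number a weaker inhibitor), compound 1 stands at > 100000 nM, which is a limit of the assay and not a number. Compound 2 likewise gives only a limit, > 100000 nM. Compound 3 also gives only a limit, > 100000 nM. What the three share is the limit of > 100000 nM in this assay, at which 3 of the 3 values shown sit. The steps among them, a step that the two limits leave unreadable from compound 1 to compound 2, a step that the two limits leave unreadable from compound 1 to compound 3 and a step that the two limits leave unreadable from compound 2 to compound 3, therefore carry no readable size; they show only that changing the halogen and its place on the carboxyphenyl ring did not bring any of the three compounds below the limit.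

Compound 4 `CC#CCn1c(N2CCC[C@@H](N)C2)nc2c1c(=O)n(Cc1c(Cl)cccc1C(=O)O)c(=O)n2C` differs from compound 1 by 2-carboxy-6-chlorophenyl in place of 2-carboxy-3-fluorophenyl on a saturated chain carbon bound to an aromatic nitrogen. The measured steps bear on it only by analogy: each earlier exchange on the same ring left the value at the limit, so no step beyond the scatter in either direction is expected here. Compound 4 is thus expected to sit at about 100000 nM, within 30000 nM to 300000 nM. The step this estimate implies is expected to be a number no higher from compound 1 to compound 4 (the limit leaves the size open).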

Compound 4, half-maximal inhibitory concentration: > 100000 nM
Compound 4 ended at the assay's limit; the forecaster's own chance of this, stated with the estimate: 85%; the middle value lies on the limit itself.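

No step can be read from compound 4 to compound 1, compound 2 or compound 3, because all four stop at a limit and not at a number: the limit of > 100000 nM in this assay, at which 4 of the 4 values shown sit.

The compounds shown leave open how far any of the four lies beyond that limit.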